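Amide nitrogen substituent swap on the shared core: cytotoxicity notes

The source may hold more compounds than are shown below. What is called first, only, known or untested is meant among the compounds shown, and "the series" means these compounds.

Compound 1 `O=C(/C=C/c1coc2cc(O)ccc2c1=O)NCc1ccccc1` gives 436000 nM in an ADME assay on HepG2 2.2.15 cells (Homo sapiens) for cytotoxicity, read by MTT assay, with stated times of 48 h and 9 days; on this read-out higher numbers stand for lower toxicity in this test and lower numbers for higher toxicity in this test. For the measured compounds named here, compound 3 `COc1ccc(NC(=O)/C=C/c2coc3cc(O)ccc3c2=O)cc1` gives 976000 nM, and the one-place step a 2.2-fold higher number from compound 1 to compound 3 (0.35 log units; beyond the scatter) is the only measured step. Compound 2 `COc1ccc2c(=O)c(/C=C/C(=O)Nc3cc(C)ccc3C)coc2c1` gives 1100000 nM, the highest of the three numbers; against compound 3 the two values sit within the scatter, while against compound 1 the gap is beyond it.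

Compound 4 `COc1ccc2c(=O)c(/C=C/C(=O)NCc3ccc(F)cc3F)coc2c1` is not yet measured. It differs from compound 2 by 2,4-difluorobenzyl in place of 2,5-dimethylphenyl on an amide-type nitrogen. The step from compound 1 to compound 3 bears on this, since it also exchanges the group on the amide nitrogen, and it was modest. Reversing the sense of that exchange, a small lower number, likely within the scatter, is expected: compound 4 is estimated at 800000 nM (range 400000 nM to 1600000 nM). The expected step is a 1.4-fold lower number from compound 2 to compound 4 (0.14 log units; within the scatter).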

Compound 4, half-maximal cytotoxic concentration: 79300 nM
Compound 4: middle estimate off by 10-fold (1.00 log units), on the high side, outside the stated range (below it).
By their numbers in this assay, from the lowest: compound 4; then compound 1; then compounds 3 and 2 (each within the scatter of the next).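

In this assay, for the compounds shown here, the group on this amide-type nitrogen can move the number far more than the earlier compounds showed, with a 14-fold lower number from compound 2 to compound 4 (1.14 log units; beyond the scatter). The direction matches a 2.2-fold higher number from compound 1 to compound 3 (0.35 log units; beyond the scatter), since the benzyl-type group carries the lower number in both pairs, but the size of the step is much larger here. No measured evidence accompanies this result to account for the difference in size.

The compounds shown do not separate the contribution of the two fluorines from that of the benzyl linkage. On these data alone, how a phenethyl group on this nitrogen would read on the shared core remains open.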